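Methyl additions on the bicyclic core of two aryl-substituted series

A few compounds are considered here, and "the series" means these few. Any claim that something is new, unique, unknown or untested is made for them only; others in the source may bear on it.

Compound 3 `COc1cccc(-c2cc(O)c3c(C)ccnc3n2)c1` is the reference point: in a functional assay on SF-295 cells (Homo sapiens) (a higher number here means a weaker inhibitor of growth, a lower number a stronger inhibitor of growth), compound 3 gives 28.8 nM. Compound 1 `COc1cccc(-c2cc(O)c3c(C)cc(C)nc3n2)c1` carries one more methyl group and in this assay compound 1 gives 417 nM; the change is methyl in place of hydrogen on an aromatic carbon, and the step is a 14-fold higher number from compound 3 to compound 1 (1.16 log units; beyond the scatter). Compound 2 `COc1ccccc1-c1cc(O)c2cccnc2n1` belongs to a second set; in this assay compound 2 gives 23400 nM, the highest number among the three measured compounds. The difference between the core of compound 2 and the core of compound 3 is not broken down here.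

Compound 4 `COc1ccccc1-c1cc(O)c2cc(C)cnc2n1` is not yet measured. It differs from compound 2 by methyl in place of hydrogen on an aromatic carbon. This is the same kind of change as that from compound 3 to compound 1, but not the same: there the methyl enters next to the ring nitrogen and meta to a methyl group, here it enters two atoms from the ring nitrogen with no methyl group nearby. The expected step in this assay is a 2.6-fold higher number from compound 2 to compound 4 (0.41 log units; beyond the scatter), resting on a 14-fold higher number from compound 3 to compound 1 (1.16 log units; beyond the scatter) but tempered by the differing surroundings. For compound 4 the estimate is 60000 nM, between 15000 nM and 250000 nM.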

Compound 4, concentration for 50% growth inhibition: 30900 nM
Compound 4: the middle estimate sits 1.9-fold (0.29 log units) above what was measured, within the range that was stated.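

In this assay, the methyl group placed two atoms from the ring nitrogen gives a 1.3-fold higher number from compound 2 to compound 4 (0.12 log units; within the scatter), so on this core the change has no effect that can be told from the scatter. The same kind of change does not carry over at one size between these two cores: the same change on two cores in this assay, a 14-fold higher number (1.16 log units; beyond the scatter) from compound 3 to compound 1 and a 1.3-fold higher number (0.12 log units; within the scatter) from compound 2 to compound 4, 11-fold (1.04 log units) apart, beyond the scatter of two such steps

This does not show whether the core or the place of the methyl group sets the gap, since the two steps differ in both, and one pair per core gives no general rule for the series.

Still open, from the compounds shown here alone, is whether a methyl group at one and the same place on both cores would give steps of similar size. Also open, going by these compounds, is whether a larger or different group two atoms from the ring nitrogen, such as an ethyl chain, an amine or a carboxylic acid, would move the number on the core of compound 2 beyond the scatter.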